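The source may hold more compounds than are shown below. What is called first, only, known or untested is meant among the compounds shown, and "the series" means these compounds.

Working notes on a series sharing one core, on which a substituted phenyl sits on a ring nitrogen. Compound 1 `CCCCN(CC)c1cc(C)nc2c1NC(=O)CN2c1ccc(C)cc1Cl` gives "not determined" (no result reported) in an assay on HEK-293T cells for displacement of a labelled ligand from corticotropin-releasing factor receptor 2 (Homo sapiens), read by scintillation counting, with a stated time of 2 h, tested at 1 uM (a higher number here means more inhibition at the concentration tested (going by the name of the read-out), a lower number less inhibition), so it has no result there. Compound 2 `CCCCN(CC)c1cc(C)nc2c1NC(=O)CN2c1ccc(OC)cc1C` gives -2.3% in this assay, a read-out that is indistinguishable from no inhibition at the tested concentration. Compound 3 `CCCCN(CC)c1cc(C)nc2c1NC(=O)CN2c1ccc(I)cc1C` gives "not determined" (no result reported) in this assay, so it likewise stands without a number of its own, and only compound 2 supplies a measured reference for the series.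

Compound 4 `CCCCN(CC)c1cc(C)nc2c1NC(=O)CN2c1ccc(Br)cc1CC` has not yet been measured. It differs from compound 3 by 4-bromo-2-ethylphenyl in place of 4-iodo-2-methylphenyl on a nitrogen on an aromatic ring in a ring. For the measured compounds named here, no measured step exists between compound 3 and compound 4, and there is no measured step between any two compounds in this assay. Given that compound 2 gives -2.3%, no step beyond the scatter is expected for this change in this assay, in either direction. Compound 4 is therefore expected to give about 3% in this assay, with a plausible range from -12% to 20%.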

Compound 4, a percentage reported as inhibition, at one concentration (the size of the read-out at that concentration, not a potency): 2.1%
Estimate against measurement, compound 4: 0.9 percentage points above; the range from low to high includes it.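

In this assay, for the compounds shown here, the exchange of 4-methoxy-2-methylphenyl for 4-bromo-2-ethylphenyl on the ring nitrogen gives a number 4.4 percentage points higher from compound 2 to compound 4 (within the scatter), the first step that can be read at this position, and it does not separate the two groups. Steps involving compound 1 or compound 3 cannot be read, since neither has a number. Nothing available explains this result.

The compounds shown leave open whether any group at this position gives a read-out beyond the scatter from these two, for instance a phenyl bearing a carboxylic acid or an amine, or a longer chain in place of the ethyl. With a read-out at a single concentration, they also leave open how compound 2 and compound 4 would behave at higher concentrations.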